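The compounds below may be only part of what the source reports. "The series", "measured", "known", "first", "only" and "open" are said of these compounds alone.

Compound 1, `O=C(Nc1cccc(-c2cccc(NC(=O)C(Cl)Cl)c2)c1)C(Cl)Cl`: in a functional assay on KB 3-1 cells (Homo sapiens) for cytotoxicity, read by MTT assay, with a stated time of 68 h (a higher number here means a weaker inhibitor, a lower number a stronger inhibitor), compound 1 gives > 50000 nM, a limit of the assay.
Compound 2, `CSc1cccc(-c2cc(NC(=O)C(Cl)Cl)cc(-c3cccc(SC)c3)c2)c1`: in this assay compound 2 gives > 30000 nM, a limit of the assay.
Compound 3, `O=C(Nc1cccc(-c2cccc(F)c2)c1)C(Cl)Cl`: in this assay compound 3 gives > 50000 nM, a limit of the assay.

Compound 3 thus stands where all three measured compounds stand: it has only a limit and no number, and the two further values shown are limits too. Among the measured compounds shown here, the single step between measured compounds that differ in one place, a step that the two limits leave unreadable from compound 1 to compound 3, cannot be read in size, because the limit of > 50000 nM in this assay, at which 2 of the 3 values shown sit, is where both of its ends sit. The third value sits at the limit of > 30000 nM in this assay, at which 1 of the 3 values shown sits.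

For the measured compounds named here, compound 4, `Nc1cccc(-c2cccc(NC(=O)C(Cl)Cl)c2)c1`, is not yet measured. amino in place of fluoro on an aromatic carbon No measured step bears on this change in a readable way, since the only step available gives no size. What the three measured compounds do show is that every value on this shared core is a limit, and compound 3 carries the same core as compound 4. The step of a number no higher from compound 3 to compound 4 (the limit leaves the size open) is therefore expected to be none beyond the scatter. Compound 4 is expected to give 50000 nM, within a range from 10000 nM to 200000 nM, most likely reported again only as a limit.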

Compound 4, half-maximal inhibitory concentration: 26100 nM
For compound 4 the middle estimate is 1.9-fold (0.28 log units) above the measured one; the range from low to high includes it.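

Among the compounds shown here, with amino in place of fluoro on this aromatic carbon, meta to a large group, compound 4 gives 26100 nM in this assay, the only value shown on these compounds that is a number and not a limit. The change itself is an at least 1.9-fold lower number from compound 3 to compound 4 (0.28 log units; that floor lies within the scatter), and taking the (dichloromethyl)carbonyl off the nitrogen of compound 1, which leaves the same amino group, is an at least 1.9-fold lower number from compound 1 to compound 4 (0.28 log units; that floor lies within the scatter). Each of these is only a floor and may stand for a small step or a much larger one, and the true size stays open because compound 1 and compound 3 both start from a limit: the limit of > 50000 nM in this assay, at which 2 of the 4 values shown sit.

The step between compound 1 and compound 3 cannot be read, so the compounds shown do not rank fluoro against ((dichloromethyl)carbonyl)amino on this carbon, and they give no second number to compare compound 4 with. Going by these compounds, whether a dimethylamino group, a hydroxyl group or a carboxylic acid on the same aromatic carbon would also give a measurable number in this assay, or whether this is particular to the amino group, remains open.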